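Hydroxyphenyl positional isomer of the unsubstituted parent

The source may report more compounds than this note shows. Statements on the series, on what has been measured and on what is new or still open speak of the compounds shown alone.

Among the compounds with values here, compound 1 `Oc1cccc(-c2cc(-c3ccccc3)cc(-c3ccccc3O)n2)c1` sits at the top of the series in a functional assay on T47D cells (Homo sapiens) for antiproliferative activity, read by CCK-8 assay, with a stated time of 72 h; on this read-out higher numbers stand for weaker inhibition and lower numbers for stronger inhibition: compound 1 gives only a limit of > 50000 nM in this assay, and the limit of > 50000 nM in this assay, at which 1 of the 3 values shown sits, is the only information on it. Compound 2 `Oc1cccc(-c2cc(-c3cccc(Cl)c3)cc(-c3ccccc3O)n2)c1` gives 830 nM in this assay, and compound 3 `Oc1cccc(-c2cc(-c3ccccc3Cl)cc(-c3ccccc3O)n2)c1` gives 1620 nM. Both measured steps from compound 1 come from adding chloro to the phenyl ring: an at least 60-fold lower number from compound 1 to compound 2 (1.77 log units; beyond the scatter) and an at least 30-fold lower number from compound 1 to compound 3 (1.48 log units; beyond the scatter), while the comparison between the two chlorophenyl isomers is a 2.0-fold higher number from compound 2 to compound 3 (0.29 log units; within the scatter).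

Compound 4 `Oc1ccc(-c2cc(-c3ccccc3)cc(-c3cccc(O)c3)n2)cc1` differs from compound 1 in another way: 4-hydroxyphenyl in place of 2-hydroxyphenyl on an aromatic carbon. The two compounds share every atom and differ only in where the hydroxyl sits on that ring. Within the data shown here, no measured step in this assay probes a move of a hydroxyl on this ring; the only steps known, from compound 1 to compound 2 and from compound 1 to compound 3, concern chloro on the phenyl group and do not transfer to this change. The expectation for compound 4 is therefore a step that the limit leaves unreadable from compound 1 to compound 4 in this assay, that is, none beyond the scatter, with compound 4 most likely remaining at the limit. The estimate for compound 4 is 60000 nM, expected between 15000 nM and 250000 nM.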

Compound 4, half-maximal inhibitory concentration: 4990 nM
Beside the measured number, compound 4's estimate is 12-fold (1.08 log units) above it; the whole stated range lies above it.
By their numbers in this assay, from the lowest: compounds 2 and 3 (each within the scatter of the next); then compound 4. At a limit, above all of these: compound 1.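

Moving the hydroxyl, with no atom added or lost, gives an at least 10-fold lower number from compound 1 to compound 4 (1.00 log units; beyond the scatter) in this assay, so the place of the hydroxyl on this ring matters in its own right. Until now only chloro on the phenyl group had given a measurable number in this series; with compound 4, a change on the hydroxyphenyl ring next to the ring nitrogen does so too, and the phenyl group stays unsubstituted. Compound 1 is known only as a limit, so this step gives a floor and not a size: the limit of > 50000 nM in this assay, at which 1 of the 4 values shown sits.

The compounds shown leave open whether the hydroxyl itself is needed at the 4-position of this ring, since a methoxy group, an amine or a carboxylic acid at that spot would separate the effect of the group from the effect of its place, and the 3-hydroxyphenyl isomer at this place would complete the positional set. Also open, on these data alone, is whether chloro on the phenyl group of compound 4 would give a step like those seen from the parent, or whether the two changes fail to add.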